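Sulfur substituent change from compound 2 to compound 3

The compounds below may be only part of what the source reports. "The series", "measured", "known", "first", "only" and "open" are said of these compounds alone.

- compound 1 `CCc1ccc(SCc2ccc(C(=O)Nc3ccccc3N)cc2)cc1`: 82.9%
- compound 2 `Nc1ccccc1NC(=O)c1ccc(CSCCc2ccccc2)cc1`: 77.9%

In a functional assay on SMMC-7721 cells (Homo sapiens) for inhibition, read by CCK-8 assay, with a stated time of 72 h, tested at 8 uM (on this read-out higher numbers stand for more inhibition of growth at the one concentration tested and lower numbers for less inhibition of growth), compound 2 gives 77.9%, which lies within the scatter of compound 1. Compound 3 `Cc1cc(C)cc(SCc2ccc(C(=O)Nc3ccccc3N)cc2)c1` is not yet measured and carries 3,5-dimethylphenyl in place of phenethyl on a sulfur. Among the measured compounds shown here, one measured step bears on this change: a number 5 percentage points lower from compound 1 to compound 2 (within the scatter), with phenethyl in place of 4-ethylphenyl on a sulfur. Since that step is small, no shift beyond the scatter is expected in this assay. The expected change is a number 2.1 percentage points higher from compound 2 to compound 3 (within the scatter). For compound 3 the estimated value is 80%, with an expected range of 70% to 90%.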

Compound 3, percent growth inhibition at one concentration: 85.1%
The estimate for compound 3 lay 5.1 percentage points below the measured number, and the stated range covers the measured number.
By their numbers in this assay, from the lowest: compounds 2, 1 and 3 (each within the scatter of the next).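

In this assay, replacing phenethyl on the sulfur with 3,5-dimethylphenyl, a group with the same heavy-atom count, stays inside the scatter: a number 7.2 percentage points higher from compound 2 to compound 3 (within the scatter). Against the other aryl group the picture is the same: a number 2.2 percentage points higher from compound 1 to compound 3 (within the scatter). All three carbon-only groups on this sulfur therefore read alike at the one concentration tested, and no evidence available here bears on why.

As far as these compounds go, whether a sulfur substituent carrying an amine or a carboxylic acid would separate from these three remains open. So does whether these three would separate at a lower concentration.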